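Fluoro for methyl on the pendant ring of a chromanone series

A few compounds are considered here, and "the series" means these few. Any claim that something is new, unique, unknown or untested is made for them only; others in the source may bear on it.

Measured compounds:
compound 1 `O=C1C[C@H](c2ccc(F)cc2)Oc2cc(F)ccc21`, 150 nM
compound 2 `Cc1ccc([C@@H]2CC(=O)c3ccc(C)cc3O2)cc1`, 590 nM
compound 3 `Cc1ccc([C@@H]2CC(=O)c3ccc(F)cc3O2)cc1`, 150 nM

In an in vitro assay on BTI-TN-5B1-4 cells for inhibition of Amine oxidase [flavin-containing] B (Homo sapiens) (on this read-out lower numbers stand for stronger inhibition and higher numbers for weaker inhibition), compound 3 gives 150 nM, level with compound 1 at the digits shown and together with it the lowest of the three numbers; compound 2 sits furthest away, with the higher number. Within the data shown here, the one single-point step measured so far, a 3.9-fold lower number from compound 2 to compound 3 (0.59 log units; beyond the scatter), swaps a methyl for a fluoro on an aromatic carbon of the shared core.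

Compound 4 `O=C1C[C@@H](c2ccc(F)cc2)Oc2cc(F)ccc21` repeats that kind of swap on the other aromatic ring: fluoro in place of methyl on an aromatic carbon. Among the measured compounds shown here, only the step from compound 2 to compound 3 bears on it, and it was modest. Compound 1, which carries fluoro on both rings, gives 150 nM, no different from compound 3 at the digits shown. Compound 4 is therefore expected to land close to compound 3, with at most a small step, a 1.3-fold lower number from compound 3 to compound 4 (0.10 log units; within the scatter). The estimate for compound 4 in this assay is 120 nM, within the range 50 nM to 300 nM.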

Compound 4, half-maximal inhibitory concentration: 170 nM
The estimate for compound 4 lay 1.4-fold (0.15 log units) below the measured number; measured number inside the range.
By their numbers in this assay, from the lowest: compounds 1, 3 and 4 (each within the scatter of the next); then compound 2.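

In this assay, fluoro in place of methyl on this aromatic carbon, para to a large group, gives a 1.1-fold higher number from compound 3 to compound 4 (0.05 log units; within the scatter), whereas the same kind of swap on the other aromatic ring gave a 3.9-fold lower number from compound 2 to compound 3 (0.59 log units; beyond the scatter). Among these compounds, then, the swap is read differently at the two places, and only the earlier one moves the number beyond the scatter. The second new step, a 1.1-fold higher number from compound 1 to compound 4 (0.05 log units; within the scatter), also stays within the scatter, and it can be read as a change of drawn configuration alone at the saturated ring carbon, on this basis: the fact that compounds 1 and 4 differ only in the configuration as drawn.

The compounds shown leave open how a methoxy group, a chloro group or an amine on this aromatic carbon would read in this assay. They also leave open whether the drawn configuration stays without a visible step when methyl rather than fluoro sits here.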